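The compounds below may be only part of what the source reports. "The series", "measured", "known", "first", "only" and "open" are said of these compounds alone.

Working notes on the series.

Compound 1 `Cn1c(NN)nc(-c2cccc(O)c2O)c(C#N)c1=O` is the reference. In a functional assay, with a stated time of 10 min (on this read-out lower numbers stand for stronger inhibition and higher numbers for weaker inhibition), compound 1 gives 29 ug/mL. Two further compounds have been measured: compound 2 `CN(C)c1ccc(-c2nc(NN)n(C)c(=O)c2C#N)cc1` gives 66 ug/mL in this assay, and compound 3 `COc1cccc(-c2nc(SC)n(C)c(=O)c2C#N)c1OC` gives 43 ug/mL. Of the three numbers, compound 1 and compound 3 lie within the usual scatter of each other, so nothing separates them; compound 2 sits beyond the scatter on the weaker side of compound 1.

The next compound is compound 4 `CSc1nc(-c2cccc(O)c2O)c(C#N)c(=O)n1C`. Relative to compound 1 the change is methylsulfanyl in place of aminoamino on an aromatic carbon. For the measured compounds named here, no pair of measured compounds isolates this change, so the step can only be guessed. Compound 3 carries the same methylsulfanyl group and gives 43 ug/mL, which is within the scatter of compound 1, but it differs from compound 4 elsewhere as well. The step from compound 1 is therefore expected to be small, a 1.4-fold higher number from compound 1 to compound 4 (0.14 log units; within the scatter), likely within the scatter, with a slight lean towards a higher number. For compound 4 the expected value in this assay is 40 ug/mL, with a range from 15 ug/mL to 110 ug/mL.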

Compound 4, half-maximal inhibitory concentration: 37 ug/mL
The estimate for compound 4 lay 1.1-fold (0.03 log units) above the measured number, within the range that was stated.
By their numbers in this assay, from the lowest: compounds 1, 4, 3 and 2 (each within the scatter of the next, the first and the last beyond it).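

In this assay, for the compounds shown here, methylsulfanyl in place of aminoamino on the aromatic carbon between two ring nitrogen atoms gives a 1.3-fold higher number from compound 1 to compound 4 (0.11 log units; within the scatter), the first step to isolate this change. The exchange takes the count from 2 hydrogen-bond donors on aminoamino to 0 on methylsulfanyl, and with the rest of compound 1 held constant, this read-out does not separate the two groups. No supporting measurement bears on this result, so the observation stands without an explanation.

Still open, from the compounds shown here alone, is how a plain amine, a morpholine ring or a longer chain such as butylsulfanyl would read at this position. Going by these compounds, it is also open whether the same exchange stays within the scatter when the group of 8 heavy atoms carries other substituents.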